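Phenyl Replaced by Isopropyl on a Shared Core

This account rests on a few compounds, and the source may have more. Where it says the series, first, only, none or still open, it means among the compounds named here.

Three compounds have been measured in an assay on isolated protein for binding affinity to sphingosine 1-phosphate receptor 2 (Homo sapiens), read by surface plasmon resonance; on this read-out higher numbers stand for weaker binding and lower numbers for tighter binding:

Compound 1 `Cn1nc(C(F)(F)F)c2c(-c3ccccc3)cc(NNC(=O)Nc3cc(Cl)nc(Cl)c3)nc21`: 940 nM
Compound 2 `Cn1ncc2c(-c3ccc(F)cc3)cc(NNC(=O)Nc3cc(Cl)cc(Cl)c3)nc21`: 4980 nM
Compound 3 `Cn1ncc2c(-c3ccccc3)cc(NNC(=O)Nc3cc(Cl)nc(Cl)c3)nc21`: 1020 nM

Among these three numbers, compound 1 stands lowest. Its nearest neighbour is compound 3, which differs by a 1.1-fold higher number from compound 1 to compound 3 (0.04 log units; within the scatter), a change too small to separate the two in this assay. Compound 2, which differs from compound 1 in more than one place, sits furthest away, and its number shows a clearly weaker binding than compound 1.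

The unmeasured compound 4 `CC(C)c1cc(NNC(=O)Nc2cc(Cl)nc(Cl)c2)nc2c1c(C(F)(F)F)nn2C` arises from compound 1 by a single change: isopropyl in place of phenyl on an aromatic carbon. A flat aromatic ring thus gives way to a small branched chain at the same position on the core.

Among the compounds with values here, none of the measured steps touches this position, so no direct guide exists. Within the data shown here, the one single-point step known, the trifluoromethyl removal between compound 1 and compound 3, stayed within the scatter, which says nothing about the phenyl. Swapping a six-atom ring for a three-atom chain is a larger alteration, so in this assay a shift somewhat beyond the scatter toward weaker binding is expected, with wide uncertainty. Compound 4 is estimated at 1800 nM, within 500 nM to 6000 nM, meaning an expected step of a 1.9-fold higher number from compound 1 to compound 4 (0.28 log units; within the scatter).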

Compound 4, dissociation constant: 1250 nM
For compound 4 the middle estimate is 1.4-fold (0.16 log units) above the measured one, within the range that was stated.
By their numbers in this assay, from the lowest: compounds 1, 3 and 4 (each within the scatter of the next); then compound 2.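

In this assay the change from phenyl to isopropyl gives a 1.3-fold higher number from compound 1 to compound 4 (0.12 log units; within the scatter) and so does not separate the two groups. This position, opposite the ring nitrogen, therefore does not need an aromatic ring to keep the number of compound 1 in this assay: isopropyl, with no ring and 3 heavy atoms, reads the same within the scatter as phenyl, with its six-membered aromatic ring and 6 heavy atoms. Nothing shown here explains why these two different groups read alike.

The compounds shown leave open how far this tolerance reaches, and whether a methyl, a longer chain such as hexyl, an amine or a carboxylic acid on the same carbon would also hold the number in this range. They also leave open whether isopropyl would read the same on the core of compound 3, which carries hydrogen in place of the trifluoromethyl.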